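The source may hold more compounds than are shown below. What is called first, only, known or untested is meant among the compounds shown, and "the series" means these compounds.

Compound 1 `COC(C)CO[C@H](CC=C(C)C)C1=CC(=O)c2c(O)ccc(O)c2C1=O` gives 53400 nM in a functional assay on HeLa cells (Homo sapiens) for cytotoxicity, read by MTT assay; a lower number here means a stronger inhibitor, a higher number a weaker inhibitor.
Compound 2 `CC(C)=CC[C@@H](OC(=O)C1CCOC1)C1=CC(=O)c2c(O)ccc(O)c2C1=O` gives 73500 nM.
Compound 3 `CCC(O)(CC)CC(=O)O[C@H](CC=C(C)C)C1=CC(=O)c2c(O)ccc(O)c2C1=O` gives 52000 nM.

Compound 1 stands second highest of these three numbers, but its steps to the others are small: a 1.4-fold higher number from compound 1 to compound 2 (0.14 log units; within the scatter) and a 1.0-fold lower number from compound 1 to compound 3 (0.01 log units; within the scatter), both within the scatter, as is a 1.4-fold lower number from compound 2 to compound 3 (0.15 log units; within the scatter). Compound 4 `CC(=O)OC(C)CO[C@H](CC=C(C)C)C1=CC(=O)c2c(O)ccc(O)c2C1=O` has not yet been measured in this assay. It differs from compound 1 in one place: acetyl in place of methyl on an oxygen on a saturated carbon. The measured steps that bear on this change are the two from compound 1, since each of them also exchanges the group on that oxygen on a saturated carbon, replacing 2-methoxypropyl with (oxolan-3-yl)carbonyl or with (2-ethyl-2-hydroxybutyl)carbonyl, and neither moved the number beyond the scatter. The present change, acetyl in place of methyl, is a smaller alteration of that same group than either of those, so no step beyond the scatter is expected: a 1.0-fold higher number from compound 1 to compound 4 (0.01 log units; within the scatter). Compound 4 is therefore estimated at 55000 nM, with a range from 25000 nM to 120000 nM.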

Compound 4, half-maximal inhibitory concentration: 40100 nM
Compound 4: middle estimate off by 1.4-fold (0.14 log units), on the high side, and the stated range covers the measured number.
By their numbers in this assay, from the lowest: compounds 4, 3, 1 and 2 (each within the scatter of the next).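

In this assay, acetyl in place of methyl on an oxygen on a saturated carbon leaves the number within the scatter, with a 1.3-fold lower number from compound 1 to compound 4 (0.12 log units; within the scatter). Where the earlier steps exchanged the whole group on that oxygen, this change alters only the end of 2-methoxypropyl, and the resulting 2-acetoxypropyl group also stays within the scatter of both carbonyl-linked groups, with a 1.3-fold lower number from compound 3 to compound 4 (0.11 log units; within the scatter) and with a 1.8-fold lower number from compound 2 to compound 4 (0.26 log units; within the scatter). No supporting measurement is available to explain this result.

The compounds shown leave open whether an amine, a carboxylic acid or a longer chain at this place would move the number beyond the scatter. They also leave open whether a simple acetyl group directly on this oxygen would behave like the groups shown.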